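The source may hold more compounds than are shown below. What is called first, only, known or untested is meant among the compounds shown, and "the series" means these compounds.

Measured in a functional assay on MCF7 cells (Homo sapiens) for inhibition, read by CCK-8 assay, with a stated time of 48 h; on this read-out higher numbers stand for weaker inhibition of growth and lower numbers for stronger inhibition of growth:
Compound 1 `CC(C)c1ccccc1Nc1nc(Nc2ccc(N3CCN(C)CC3)cn2)ncc1Cl`: 4360 nM
Compound 2 `CN1CCN(c2ccc(Nc3ncc(Cl)c(Nc4ccc(C(C)(C)C)cc4)n3)nc2)CC1`: 12600 nM

Compound 2 stands at the higher of these two numbers, which means the weaker inhibition of growth. A further compound, compound 3 `COc1cccc(Nc2nc(Nc3ccc(N4CCN(C)CC4)cn3)ncc2Cl)c1`, is still unmeasured. It keeps the shared core and changes one group: 3-methoxyphenyl in place of 4-(tert-butyl)phenyl on a nitrogen on an aromatic ring. In words, 3-methoxyphenyl takes the place of 4-(tert-butyl)phenyl on a nitrogen on an aromatic ring. Among the measured compounds shown here, only one measured step bears on this change, and it concerns the same place: a 2.9-fold higher number from compound 1 to compound 2 (0.46 log units; beyond the scatter). That step was modest and brought in 4-(tert-butyl)phenyl, so removing this group from compound 2 may be expected to undo a similar amount. For the measured compounds named here, this is thin evidence, as no measured compound carries 3-methoxyphenyl. A modest drop is expected, estimated as a 2.1-fold lower number from compound 2 to compound 3 (0.32 log units; beyond the scatter). For compound 3 the expected value is 6000 nM, with an estimated range of 2500 nM to 14000 nM.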

Compound 3, concentration for 50% growth inhibition: 7540 nM
Beside the measured number, compound 3's estimate is 1.3-fold (0.10 log units) below it, and the stated range covers the measured number.
By their numbers in this assay, from the lowest: compounds 1, 3 and 2 (each within the scatter of the next, the first and the last beyond it).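

In this assay the 3-methoxyphenyl group gives a 1.7-fold lower number from compound 2 to compound 3 (0.22 log units; within the scatter) and a 1.7-fold higher number from compound 1 to compound 3 (0.24 log units; within the scatter) and so cannot be separated from either earlier compound. The two earlier compounds do lie beyond the scatter of each other, so a group containing oxygen fits at this place on the nitrogen with a number that sits within the scatter of both. Nothing shown gives a reason for this result.

As far as these compounds go, all three groups here are phenyl rings carrying a carbon or oxygen substituent, so it remains open how this growth read-out would respond to an amine or a carboxylic acid on that ring. A plain phenyl or a cyclohexyl ring at the same place is also an open case.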